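The compounds below may be only part of what the source reports. "The series", "measured", "known", "first", "only" and "open" are said of these compounds alone.

Working notes on the series in a functional assay on SH-SY5Y cells (Homo sapiens) for cytotoxicity, read by MTT assay, with a stated time of 72 h; a higher number here means a weaker inhibitor, a lower number a stronger inhibitor.

The parent, compound 1 `O=C1c2c[n+]([O-])c3ccccc3c2C(=O)c2[nH]c3ccccc3c21`, gives 1380 nM in this assay. Two analogues carry a substituent on the aromatic nitrogen: compound 2 `O=C1c2c[n+]([O-])c3ccccc3c2C(=O)c2c1c1ccccc1n2CCCCN1CCCCC1` gives 230 nM, and compound 3 `CN(C)CCCCCn1c2c(c3ccccc31)C(=O)c1c[n+]([O-])c3ccccc3c1C2=O` gives 370 nM. Both steps from the parent lower the number, a 6.0-fold lower number from compound 1 to compound 2 (0.78 log units; beyond the scatter) and a 3.7-fold lower number from compound 1 to compound 3 (0.57 log units; beyond the scatter), so the substituted pair sits well apart from compound 1. Between the two substituted compounds the difference is small, a 1.6-fold higher number from compound 2 to compound 3 (0.21 log units; within the scatter), so compound 3 stands second highest of the three numbers but cannot be separated from compound 2 on the data shown.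

Compound 4 `O=C1c2c[n+]([O-])c3ccccc3c2C(=O)c2c1c1ccccc1n2CCCCn1ccnc1` is unmeasured. It differs from compound 3 as follows: 1H-imidazol-1-yl in place of (dimethylamino)methyl on a saturated chain carbon, four bonds along the chain from an aromatic nitrogen. Among the measured compounds shown here, the only step that bears on the new compound is the one between the two chain ends already compared, which exchanged one terminal group for another at the same chain position and stayed within the scatter. On that basis, compound 4 is expected to behave like compound 3 in this assay, with a step of a 1.1-fold higher number from compound 3 to compound 4 (0.06 log units; within the scatter) and no change beyond the scatter. The estimate for compound 4 in this assay is 420 nM, with a range from 200 nM to 900 nM.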

Compound 4, half-maximal inhibitory concentration: 130 nM
The estimate for compound 4 lay 3.2-fold (0.51 log units) above the measured number; the measured number lies below the stated range.
By their numbers in this assay, from the lowest: compounds 4, 2 and 3 (each within the scatter of the next, the first and the last beyond it); then compound 1.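

In (this assay), 1H-imidazol-1-yl in place of (dimethylamino)methyl, on a saturated chain carbon four bonds along the chain from an aromatic nitrogen, gives (a 2.8-fold lower number from compound 3 to compound 4 (0.45 log units; beyond the scatter)), the only exchange of chain ends shown that passes the scatter. Set against the piperidin-1-yl end, the same group gives (a 1.8-fold lower number from compound 2 to compound 4 (0.25 log units; within the scatter)), so those two compounds cannot be separated and the chain end matters only for the pair with the dimethylamino end. Among the compounds shown here, the full 4-(1H-imidazol-1-yl)butyl group in place of hydrogen on an aromatic nitrogen gives (an 11-fold lower number from compound 1 to compound 4 (1.03 log units; beyond the scatter)), the only step from compound 1 printed as large.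

No evidence is at hand to account for these differences. Still open is how a carboxylic acid, a morpholine or a shorter chain would read at this position, since only three chain ends are shown.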